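The compounds below may be only part of what the source reports. "The series", "measured", "known", "first", "only" and "open" are said of these compounds alone.

Within the data shown here, in a physicochemical assay for lipophilicity, at pH 7.4 (on this read-out lower numbers stand for lower lipophilicity and higher numbers for higher lipophilicity), only two compounds sharing a core have numbers so far. Compound 2 `Cc1ccc2nc(NC(=O)c3ccc(C(C)(C)C)cc3)cn2c1` gives 3.78 and so holds the lower position, while compound 1 `CC(C)(C)c1ccc(C(=O)Nc2cn3cc(-c4ccccc4)ccc3n2)cc1` gives 4.83 as the higher number. Compound 3 `CC(C)(C)c1ccc(C(=O)Nc2cn3cc(Cl)ccc3n2)cc1` has not been measured yet. It differs from compound 2 by chloro in place of methyl on an aromatic carbon of a six-membered aromatic ring with 1 nitrogen (chloro in place of methyl on an aromatic carbon). Among the measured compounds shown here, only one measured step bears on this change, and it is a different exchange: a number 1.05 log units lower from compound 1 to compound 2 (beyond the scatter) when methyl took the place of phenyl. That large step took away a ring, whereas the new change involves no ring, so it serves only as a loose ceiling on size. For the measured compounds named here, no measured compound carries chloro, which leaves the direction uncertain. A much smaller move is expected, slightly upward and possibly not beyond the usual scatter, and the estimated change is a number 0.20 log units higher from compound 2 to compound 3 (within the scatter) in this comparison. For compound 3 the estimated value in this assay is 3.98 with 3.6 to 4.35 as the expected range.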

Compound 3, distribution coefficient: 4.04
Estimate against measurement, compound 3: 0.06 log units below; low and high end bracket the measured number.
By their numbers in this assay, from the lowest: compounds 2 and 3 (each within the scatter of the next); then compound 1.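

In this assay chloro in place of methyl on this aromatic carbon gives a number 0.26 log units higher from compound 2 to compound 3 (within the scatter) and so the two groups cannot be told apart on this read-out. Chloro in place of phenyl at the same place gives a number 0.79 log units lower from compound 1 to compound 3 (beyond the scatter) and this adds a second case to the earlier exchange of phenyl for methyl: with either methyl or chloro on this carbon, the number stands clearly under that of compound 1, so among these three compounds the real separation lies between phenyl and the other two groups, not between methyl and chloro. No measurement at hand offers a reason for these numbers.

Left open is where an amine, a carboxylic acid or a longer chain on this same aromatic carbon would fall relative to the three numbers now in hand. Also open, from the compounds shown here alone, is whether chloro in place of methyl would read the same way on another carbon of the shared core, since this exchange has been seen at only one place.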